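Swapping a Methoxyphenyl for an Oxadiazole on a Furoic Acid

A few compounds are considered here, and "the series" means these few. Any claim that something is new, unique, unknown or untested is made for them only; others in the source may bear on it.

Of the compounds shown here, two sharing one furan-based core have been tested in an assay on cells for displacement of a labelled ligand from prostaglandin E2 receptor EP4 subtype (Homo sapiens), read by scintillation counting; on this read-out lower numbers stand for stronger inhibition and higher numbers for weaker inhibition. Compound 1, `Cc1oc(C(=O)NS(=O)(=O)c2ccccc2)cc1COc1ccc(-c2ccccc2)cc1`, carries an acylsulfonamide and an unsubstituted phenyl on its far ring; in this assay compound 1 gives 25 nM. Compound 2, `COc1ccccc1-c1ccc(OCc2cc(C(=O)O)oc2C)cc1`, instead has a free carboxylic acid and a 2-methoxyphenyl, and in this assay compound 2 gives 1600 nM. Compound 2 thus shows the higher of the two numbers, and the gap to compound 1 lies well beyond the usual scatter. Since the two differ in more than one place, neither change can be credited on its own.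

Compound 3, `Cc1oc(C(=O)O)cc1COc1ccc(-c2nnco2)cc1`, keeps the carboxylic acid of compound 2 and changes only the distal group: 1,3,4-oxadiazol-2-yl in place of 2-methoxyphenyl on an aromatic carbon. Among the compounds with values here, no measured pair isolates this kind of exchange, so any expectation is loose. The 2-methoxyphenyl is replaced by a much smaller five-membered heteroaromatic, and the step from compound 2 to compound 3 is expected to be a modest rise in the number, a 2.2-fold higher number from compound 2 to compound 3 (0.34 log units; beyond the scatter), though a change within the scatter cannot be ruled out. Compound 3 is therefore expected to give about 3500 nM, somewhere between 900 nM and 14000 nM.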

Compound 3, inhibition constant: > 10000 nM
Compound 3: a limit, no number; the forecaster's own chance of this, stated with the estimate: 20%; middle value at least 2.8-fold (0.45 log units) from the limit.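

In this assay, replacing the 2-methoxyphenyl with 1,3,4-oxadiazol-2-yl gives an at least 6.2-fold higher number from compound 2 to compound 3 (0.79 log units; beyond the scatter), and this is the first pair shown that differs in one place only. With the carboxylic acid held fixed, the group on this aromatic carbon, para to a large group, clearly matters to the read-out, and this exchange moves the number in the weaker direction. The result for compound 3 is a limit of the assay and not a number, so the step gives only a minimum size for the change, and how much weaker compound 3 really is stays unknown: the limit of > 10000 nM in this assay, at which 1 of the 3 values shown sits.

The exchange alters ring size, the hetero atoms and the count of hydrogen-bond acceptors all at once, so these compounds cannot show which of these changes accounts for the step. A pyridyl at this position would keep a six-membered ring while bringing in a nitrogen, and an oxadiazole paired with the acylsulfonamide of compound 1 would show whether the same exchange carries the same penalty on that other core.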